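The source may hold more compounds than are shown below. What is called first, only, known or untested is meant among the compounds shown, and "the series" means these compounds.

Compound 1, `Cc1ccc(S(=O)(=O)N[C@@H](CC(=O)NC(C)(C)C)C(=O)NCCNC(=O)c2cccc(O)c2)cc1`, in an ADME assay on HepG2 cells (Homo sapiens) for cytotoxicity (a higher number here means that more compound is needed for the effect, a lower number that less compound is needed), gives > 11000 nM, a limit of the assay rather than a number.
Compound 2, `Cc1ccc(S(=O)(=O)N[C@@H](CC(=O)NC(C)(C)C)C(=O)NCCNC(=O)c2ccccc2F)cc1`, in this assay gives > 11000 nM, again a limit.
Compound 3, `Cc1ccc(S(=O)(=O)N[C@@H](CC(=O)NC(C)(C)C)C(=O)NCCNC(=O)c2cc(Cl)ccc2Cl)cc1`, in this assay gives > 11000 nM, also a limit.

Compound 3 therefore stands at the ceiling of what this assay reports, and no value among the three sets it apart, since all of them sit at the limit of > 11000 nM in this assay, at which 3 of the 3 values shown sit. The three steps between the measured compounds, a step that the two limits leave unreadable from compound 1 to compound 2, a step that the two limits leave unreadable from compound 1 to compound 3 and a step that the two limits leave unreadable from compound 2 to compound 3, are all unreadable in size. Among the compounds with values here, each of them ends at a limit on both sides, and they say only that exchanging one aryl group for another on the carbonyl carbon has not moved any compound into the measurable range.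

Compound 4, `Cc1ccc(S(=O)(=O)N[C@@H](CC(=O)NC(C)(C)C)C(=O)NCCNC(=O)c2cccc(C(F)(F)F)c2)cc1`, differs from compound 3 by 3-(trifluoromethyl)phenyl in place of 2,5-dichlorophenyl on a carbonyl carbon. Within the data shown here, the same kind of exchange is the only one that the measured steps cover, and none of them could be read, so compound 4 is expected to show a step that the limit leaves unreadable from compound 3 to compound 4, that is, no step beyond the scatter that could be told from the data. The estimate for compound 4 in this assay is 15000 nM, with a range from 7000 nM to 40000 nM, and the result is most likely to be reported again as a limit.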

Compound 4, half-maximal effective concentration: > 11000 nM
Compound 4: only a limit was reported (the forecaster's own chance of this, stated with the estimate: 80%); the middle value is on the limit's open side.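

Compound 4 also gives only a limit of the assay, so the steps to it from compound 1, compound 2 and compound 3 cannot be read, and all four compounds share one reported result: the limit of > 11000 nM in this assay, at which 4 of the 4 values shown sit.

The compounds shown leave open what value any of them would have in this assay, and whether exchanging the aryl group on the carbonyl carbon changes it at all.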